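The source may report more compounds than this note shows. Statements on the series, on what has been measured and on what is new or still open speak of the compounds shown alone.

Compound 1, `c1ccc(-c2nnco2)cc1`: > 100000 nM
Compound 2, `Sc1nnc(-c2cccc(Cl)c2)o1`: 210 nM

In an assay (Populus sieboldii x Populus grandidentata) for inhibition of Trans-cinnamate 4-monooxygenase (Populus kitakamiensis), with a stated time of 60 min (a higher number here means a weaker inhibitor, a lower number a stronger inhibitor), compound 1 gives > 100000 nM, which is a limit of the assay rather than a number (the limit of > 100000 nM in this assay, at which 1 of the 2 values shown sits). Going by the values given here, compound 2 gives 210 nM in this assay and is the only compound with a measured number here. Compound 3 `Cc1cccc(-c2nnc(S)o2)c1` differs from compound 2 by methyl in place of chloro on an aromatic carbon. No comparable step has been measured among these compounds, so only a modest shift is expected, in either direction, possibly none beyond the usual scatter. Compound 3 is estimated at 400 nM, between 150 nM and 1200 nM. This estimate corresponds to an expected step of a 1.9-fold higher number from compound 2 to compound 3 (0.28 log units; within the scatter).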

Compound 3, half-maximal inhibitory concentration: 1100 nM
Compound 3: the middle estimate sits 2.8-fold (0.44 log units) below what was measured; the range from low to high includes it.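

In this assay, swapping chloro for methyl on this aromatic carbon gives a 5.2-fold higher number from compound 2 to compound 3 (0.72 log units; beyond the scatter), so a change of a single heavy atom at this position is enough to move the result beyond the usual scatter. Of these two groups, chloro gives the stronger inhibitor. Nothing measured here bears on why the two groups differ. From the compounds shown here alone, whether an amine, a carboxylic acid or a longer chain on this carbon would give a stronger or weaker inhibitor than compound 2 stays open. So does whether the same swap elsewhere on the ring would matter as much.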